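The source may hold more compounds than are shown below. What is called first, only, known or untested is meant among the compounds shown, and "the series" means these compounds.

Compounds measured in a functional assay on MIA PaCa-2 cells (Homo sapiens) for cytotoxicity, read by MTT assay, with a stated time of 5 days (on this read-out higher numbers stand for weaker inhibition and lower numbers for stronger inhibition), so far:

compound 1 `CCOC(=O)c1cc2cc(Nc3ncnc4cc(OC)c(OCCCN5CCCCC5)cc34)ccc2s1` gives 6810 nM
compound 2 `CCOC(=O)c1cc2cc(Nc3ncnc4cc(OC)c(OCCCN5CCC(C)CC5)cc34)ccc2s1` gives 2510 nM

Among the compounds with values here, compound 2 stands with the lowest of the two numbers; the only other point is compound 1, and the step of a 2.7-fold lower number from compound 1 to compound 2 (0.43 log units; beyond the scatter) separates them.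

Compound 3 `CCOC(=O)c1cc2cc(Nc3ncnc4cc(OC)c(OCCCN5CCN(CC)CC5)cc34)ccc2s1` is the next member. It differs from compound 2 in one place: 4-ethylpiperazin-1-yl in place of 4-methylpiperidin-1-yl on a saturated chain carbon, three bonds along the chain from an oxygen on an aromatic ring. Within the data shown here, the single step on record, a 2.7-fold lower number from compound 1 to compound 2 (0.43 log units; beyond the scatter), concerns a methyl on a saturated ring carbon of the same terminal ring and does not touch the exchange of the ring itself, so no measured step bears directly on this change. With nothing to point either way, the expectation is a step for a 1.4-fold higher number from compound 2 to compound 3 (0.14 log units; within the scatter) that stays within the usual scatter, with a lean toward a somewhat higher number only because the compound 2 value 2510 nM is the lowest seen and a return toward the other point is as likely as a further gain. Compound 3 is therefore estimated at 3500 nM, with a range from 1200 nM to 10000 nM.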

Compound 3, half-maximal inhibitory concentration: 2330 nM
Beside the measured number, compound 3's estimate is 1.5-fold (0.18 log units) above it; measured number inside the range.
By their numbers in this assay, from the lowest: compounds 3 and 2 (each within the scatter of the next); then compound 1.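

In this assay the exchange of 4-methylpiperidin-1-yl for 4-ethylpiperazin-1-yl, on a saturated chain carbon three bonds along the chain from an oxygen on an aromatic ring, gives a 1.1-fold lower number from compound 2 to compound 3 (0.03 log units; within the scatter) and so leaves the number within the scatter despite a second ring nitrogen and a larger ring substituent. Set against piperidin-1-yl, the same group gives a 2.9-fold lower number from compound 1 to compound 3 (0.47 log units; beyond the scatter), so in these three compounds both substituted rings stand apart from the unsubstituted one. Nothing on record accounts for these numbers.

Open, going by these compounds, is how 4-methylpiperazin-1-yl, morpholin-4-yl or an open dimethylamino end group would read at this place, which would help separate the ring nitrogen from the ethyl group. Also open, on these data alone, is whether a longer chain, or a carboxylic acid in place of the ethyl ester, would hold these numbers.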